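Working notes: from compound 1 toward compound 4

The source may hold more compounds than are shown below. What is called first, only, known or untested is meant among the compounds shown, and "the series" means these compounds.

Compound 1 `COc1ccc(C[C@H]2COC(=O)[C@@H]2Cc2ccc(OCc3cn(Cc4ccc(Cl)cc4)nn3)c(OC)c2)cc1OC` was measured in an ADME assay on HeLa cells (Homo sapiens) for cytotoxicity, read by MTT assay (a lower number here means a stronger inhibitor, a higher number a weaker inhibitor), where compound 1 gives 242000 nM, the highest of the three numbers seen so far. Compound 2 `CCN(CC)C(=O)CCC(=O)Oc1ccc(C[C@H]2C(=O)OC[C@@H]2Cc2ccc(OC)c(OC)c2)cc1OC` gives 213000 nM in this assay, within the scatter of compound 1. Among the compounds with values here, compound 3 `COC(=O)[C@H](CC(C)C)NC(=O)CCC(=O)Oc1ccc(C[C@H]2C(=O)OC[C@@H]2Cc2ccc(OC)c(OC)c2)cc1OC` gives 53200 nM, and the only measured step, a 4.0-fold lower number from compound 2 to compound 3 (0.60 log units; beyond the scatter), concerns a substituent on a carbonyl carbon, not the ring that is altered here. Compound 4 `COc1ccc(C[C@H]2COC(=O)[C@@H]2Cc2ccc(OCc3cn(-c4ccc(C)cc4)nn3)c(OC)c2)cc1OC` differs from compound 1 by 4-methylphenyl in place of 4-chlorobenzyl on an aromatic nitrogen. Within the data shown here, no measured step bears on this aromatic nitrogen, so no shift beyond the scatter is expected. The estimated step from compound 1 is no change at the digits printed from compound 1 to compound 4 (within the scatter). Compound 4 is expected to give about 242000 nM in this assay, with a range of 110000 nM to 500000 nM.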

Compound 4, half-maximal inhibitory concentration: >= 600000 nM
Compound 4 was reported as a limit; the forecaster's own chance of this, stated with the estimate: 25%; middle value at least 2.4-fold (0.39 log units) from the limit.
By their numbers in this assay, from the lowest: compound 3; then compounds 2 and 1 (each within the scatter of the next). At a limit, above all of these: compound 4.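

In this assay, the group on this aromatic nitrogen does register: 4-methylphenyl in place of 4-chlorobenzyl gives an at least 2.4-fold higher number from compound 1 to compound 4 (0.39 log units; beyond the scatter). Compound 4 stands as a limit and not as a number: the limit of >= 600000 nM in this assay, at which 1 of the 4 values shown sits. The step thus gives a direction and a minimum size, and the swap alters both the chlorine and the benzyl form together, so neither part can be credited alone.

Going by these compounds, it remains open whether 4-chlorophenyl or 4-methylbenzyl on this nitrogen would read with compound 1 or with compound 4. On these data alone, how a benzyl bearing an amine or a carboxylic acid would read is also open.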